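The compounds below may be only part of what the source reports. "The series", "measured", "known", "first", "only" and "open" are said of these compounds alone.

Measured so far in a physicochemical assay for solubility, with a stated time of 18 h, at pH 7.4; a higher number here means a more soluble compound, a lower number a less soluble compound:

- compound 1 `COc1cccc(CNCCCNc2ccnc3cc(C4CCCCC4)ccc23)c1O` gives 4200 nM
- compound 2 `c1ccc(CCc2ccc3c(NCCCNCc4ccco4)ccnc3c2)cc1` gives 4200 nM
- compound 3 `COc1ccc(F)cc1CNCCCNc1ccnc2cc(-c3ccc(F)cc3)ccc12` gives 32000 nM

Compound 2 stands level with compound 1 at the digits shown, and the two together are the lowest of the three numbers; the gap between them lies within the scatter, so no order between them is claimed. Compound 3 sits furthest from compound 2, with a markedly higher number that lies beyond the scatter. For the measured compounds named here, no pair among the measured compounds differs in one place only, so no single measured step is available for this assay.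

Compound 4 `c1coc(CNCCCNc2ccnc3cc(CC4CCCCC4)ccc23)c1` is the next compound to be measured. It differs from compound 2 by cyclohexyl in place of benzyl on a saturated chain carbon bound to an aromatic carbon.

Nothing measured in this series tracks this particular change, so the expectation rests on the neighbours alone. Compound 1 also contains a cyclohexyl and gives 4200 nM, which is the same number as compound 2. On that basis the step of a 1.2-fold lower number from compound 2 to compound 4 (0.08 log units; within the scatter) is expected to be small, with no change beyond the scatter the most likely outcome and a slight fall somewhat more plausible than a rise. Compound 4 is therefore estimated at 3500 nM, within a range of 1200 nM to 10000 nM.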

Compound 4, solubility: 4200 nM
Compound 4: the middle estimate sits 1.2-fold (0.08 log units) below what was measured; the range from low to high includes it.
By their numbers in this assay, from the lowest: compounds 1, 2 and 4 (each within the scatter of the next); then compound 3.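

In this assay, for the compounds shown here, cyclohexyl in place of benzyl on a saturated chain carbon bound to an aromatic carbon gives no change at the digits printed from compound 2 to compound 4 (within the scatter), the first step that differs in one place only. At this position, then, a six-membered aromatic ring of carbon only and a six-membered non-aromatic ring of carbon only are not told apart by this read-out, and the same change can also be read as phenethyl to cyclohexylmethyl. No measurement at hand bears on why the two compounds do not separate.

On these data alone, this single step says nothing about groups of another kind at this place, such as an amine, a carboxylic acid or a longer chain, so whether the read-out stays flat for those remains open. As far as these compounds go, compound 3 differs from both compound 2 and compound 4 in more than one place, so its higher number in this assay cannot be assigned to any single group, and what any one of those differences contributes also stays open.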